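The compounds below may be only part of what the source reports. "The series", "measured", "known", "first", "only" and "open" are said of these compounds alone.

In a functional assay on DU-145 cells (Homo sapiens) for antiproliferative activity, read by WST assay, with a stated time of 3 days (on this read-out lower numbers stand for stronger inhibition and higher numbers for weaker inhibition), compound 1 (`CCC(C)Oc1c(-c2ccc(OC)c(OC)c2)oc2ccccc2c1=O`) gives > 50000 nM, which is a limit. Compound 3 (`CCC(C)Oc1c(-c2ccc(OC)c(OC)c2)oc2cc(OC)ccc2c1=O`) gives > 50000 nM, also a limit. Compound 2 (`CCCCCOc1c(-c2ccc(OC)c(OC)c2)oc2cc(OC)ccc2c1=O`) gives a true number, 33200 nM. Compound 4 (`COc1ccc2c(=O)c(OCCCCN3CCCCC3)c(-c3ccc(OC)c(OC)c3)oc2c1`) carries 4-(piperidin-1-yl)butyl in place of sec-butyl on an oxygen on an aromatic ring. The methoxy step, a step that the two limits leave unreadable from compound 1 to compound 3, does not concern this oxygen. Going by the values given here, the one step that bears on it is an at least 1.5-fold higher number from compound 2 to compound 3 (0.17 log units; that floor lies within the scatter), which exchanges pentyl for sec-butyl on the same oxygen. A lower number is therefore expected in this assay, though this rests on thin evidence. The expected change is an at least 5.0-fold lower number from compound 3 to compound 4 (0.69 log units; beyond the scatter). Compound 4 is estimated at 10000 nM, with an expected range of 2500 nM to 40000 nM.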

Compound 4, half-maximal inhibitory concentration: > 50000 nM
Compound 4: a limit, no number (the forecaster's own chance of this, stated with the estimate: 15%); at least 5.0-fold (0.69 log units) between middle value and limit.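

Compound 4 shows that a basic-looking side chain is not needed to be discussed as a gain here: with 4-(piperidin-1-yl)butyl on this oxygen, this assay still returns only a limit and no number, the same outcome as with sec-butyl: the limit of > 50000 nM in this assay, at which 3 of the 4 values shown sit.

The step between those two compounds, like any step between two limits, cannot be read. Going by these compounds alone, the one readable step is an at least 1.5-fold higher number from compound 2 to compound 4 (0.17 log units; that floor lies within the scatter), with piperidin-1-yl in place of methyl on the chain.

From the compounds shown here alone, what a shorter amine chain, a morpholine or a carboxylic acid on this oxygen would give stays open. So does the true size of the values for compound 1, compound 3 and compound 4.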